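A few compounds are considered here, and "the series" means these few. Any claim that something is new, unique, unknown or untested is made for them only; others in the source may bear on it.

Measured in a functional assay on MGC-803 cells (Homo sapiens) for cytotoxicity, read by MTT assay, with a stated time of 48 h; a higher number here means a weaker inhibitor, a lower number a stronger inhibitor:
- compound 1 `O=C(c1ccccc1)N1N=C(c2cc3ccccc3oc2=O)CC1c1ccccc1`: 12700 nM
- compound 2 `O=C(CNC1CC1)N1N=C(c2cc3ccccc3oc2=O)CC1c1ccccc1`: "not active" (no number reported)
- compound 3 `CC1CCCN(CC(=O)N2N=C(c3cc4ccccc4oc3=O)CC2c2ccccc2)C1`: "not active" (no number reported)

Compound 3 has no single number to stand on. In this assay, among the compounds with values here, compound 3 is recorded as "not active" (no number reported), and compound 2 is the only other compound without a number. Compound 1 alone gives a true reading, at 12700 nM.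

The next compound is compound 4 `CCN(CC)C1CCN(CC(=O)N2N=C(c3cc4ccccc4oc3=O)CC2c2ccccc2)CC1`. It keeps the shared core and the chain carbon bound to a carbonyl carbon, but 4-(diethylamino)piperidin-1-yl takes the place of 3-methylpiperidin-1-yl: 4-(diethylamino)piperidin-1-yl in place of 3-methylpiperidin-1-yl on a saturated chain carbon bound to a carbonyl carbon.

With no number for compound 3, the size of this step cannot be worked out from the data. The larger group is still a saturated amine on the same chain, so the expectation is no clear gain in this assay. Compound 4 may well be reported without a number too, and any reading is expected to be weak. Compound 4 is estimated at 25000 nM, with an expected range of 6000 nM to 90000 nM.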

Compound 4, half-maximal inhibitory concentration: 32400 nM
Compound 4: middle estimate off by 1.3-fold (0.11 log units), on the low side; the measured number falls inside the stated range.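

In this assay, within the data shown here, compound 4 is the first compound with an amine on a saturated chain carbon bound to a carbonyl carbon to give a true reading, so this kind of group is not always recorded as "not active". Putting (4-(diethylamino)piperidin-1-yl)methyl in place of phenyl on a carbonyl carbon gives a 2.6-fold higher number from compound 1 to compound 4 (0.41 log units; beyond the scatter), so this amine side chain reads weaker than the plain phenyl. Steps involving the compounds without a number cannot be read, and no measured evidence is available to explain the result.

Still open, as far as these compounds go, is how a morpholine ring on the same chain carbon would read, and whether a longer chain would shift the number. A 4-chlorophenyl group in place of phenyl on the carbonyl carbon also remains an open comparison.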